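Swapping the Thiazolylamino Group for an Isopropylcarbamoylmethyl Chain

The compounds below may be only part of what the source reports. "The series", "measured", "known", "first", "only" and "open" are said of these compounds alone.

In an assay on CHO cells for displacement of a labelled ligand from prostaglandin E2 receptor EP3 subtype (Homo sapiens), read by radioligand binding (on this read-out higher numbers stand for weaker inhibition and lower numbers for stronger inhibition), compound 3 `CC(C)C(Nc1nccs1)c1ccc(-c2ccc3cccc(F)c3c2)[nH]c1=O` gives 9.4 nM. In this assay compound 2 `CC(C)C(c1ccc(-c2ccc3cccc(F)c3c2)[nH]c1=O)N1CCCCC1=O` gives 6.4 nM, and compound 1 `CCn1ncc2c(F)cc(-c3ccc(C(CC)(CC)c4nnc[nH]4)c(=O)[nH]3)cc21` gives 17 nM. All three numbers lie within the scatter of one another, so compound 3 sits among them without any clear separation.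

Compound 4 `CC(C)NC(=O)CC(c1ccc(-c2ccc3cccc(F)c3c2)[nH]c1=O)C(C)C` differs from compound 3 by (isopropylcarbamoyl)methyl in place of (1,3-thiazol-2-yl)amino on a saturated chain carbon bound to an aromatic carbon and a saturated chain carbon. Among the compounds with values here, the only measured step at the same saturated chain carbon is a 1.5-fold higher number from compound 2 to compound 3 (0.17 log units; within the scatter), which shows that exchanging the group at that carbon left the number essentially unchanged. Judged from that single step, the expected change is a 1.5-fold higher number from compound 3 to compound 4 (0.17 log units; within the scatter), with no clear direction beyond the scatter. Compound 4 is therefore estimated at 14 nM, with a plausible range from 5 nM to 45 nM.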

Compound 4, inhibition constant: 5.8 nM
Compound 4: the middle estimate sits 2.4-fold (0.38 log units) above what was measured; measured number inside the range.
By their numbers in this assay, from the lowest: compounds 4, 2, 3 and 1 (each within the scatter of the next, the first and the last beyond it).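

In this assay the steps of a 1.6-fold lower number from compound 3 to compound 4 (0.21 log units; within the scatter) and a 1.1-fold lower number from compound 2 to compound 4 (0.04 log units; within the scatter) both lie within the scatter, so an open (isopropylcarbamoyl)methyl chain with no ring leaves the number where the two ring-bearing groups had it. At this saturated chain carbon, the three groups cannot be told apart on this read-out. Nothing available accounts for this result. On these data alone, whether a carboxylic acid, a primary amine or a longer chain at this carbon would move the number beyond the scatter remains open.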